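The compounds below may be only part of what the source reports. "The series", "measured", "known", "first", "only" and "open" are said of these compounds alone.

In a functional assay on PC-3 cells (Homo sapiens) for inhibition, read by MTT assay, with a stated time of 72 h (on this read-out higher numbers stand for weaker inhibition and lower numbers for stronger inhibition), three compounds of one series have been measured. Compound 1 `CC(C)n1ncc2c(C(=O)Nc3cccnc3)cccc21` gives only a limit, > 40000 nM. Compound 2 `CC(C)n1ncc2c(C(=O)NCc3ccccc3)cccc21` gives 15200 nM. Compound 3 `CC(C)n1ncc2c(C(=O)NCc3cn(-c4cccc(Br)c4)nn3)cccc21` gives 33700 nM, the higher of the two numbers that are not limits; its nearest neighbour is compound 2, and the gap between them lies beyond the scatter. Within the data shown here, the single step that can be read from the measured compounds, an at least 2.6-fold lower number from compound 1 to compound 2 (0.42 log units; beyond the scatter), concerns a change on an amide-type nitrogen, a different place from the one where compound 4 departs from compound 3.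

Compound 4 `COc1ccc(-n2cc(CNC(=O)c3cccc4c3cnn4C(C)C)nn2)cc1` differs from compound 3 by 4-methoxyphenyl in place of 3-bromophenyl on an aromatic nitrogen. Among the measured compounds shown here, no measured step touches this place, so the data give no ground for a shift in either direction. Compound 4 is therefore expected to stay close to compound 3, with the step of a 1.1-fold lower number from compound 3 to compound 4 (0.05 log units; within the scatter) expected to fall within the scatter. The estimate for compound 4 in this assay is 30000 nM, with a range from 12000 nM to 80000 nM.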

Compound 4, half-maximal inhibitory concentration: 34300 nM
Beside the measured number, compound 4's estimate is 1.1-fold (0.06 log units) below it; the measured number falls inside the stated range.
By their numbers in this assay, from the lowest: compound 2; then compounds 3 and 4 (each within the scatter of the next). At a limit, above all of these: compound 1.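

Among these compounds, the step, a 1.0-fold higher number from compound 3 to compound 4 (0.01 log units; within the scatter), is the first reading at this place, on an aromatic nitrogen of the five-membered ring, and it lies within the scatter. In this assay, 4-methoxyphenyl and 3-bromophenyl therefore cannot be told apart, even though the exchange removes the bromine and brings in an oxygen and a hydrogen-bond acceptor. Compound 1 gives only a limit, which marks how far the numbers of this series reach in this assay: the limit of > 40000 nM in this assay, at which 1 of the 4 values shown sits.

As far as these compounds go, it remains open whether any group on this aromatic nitrogen can move the number beyond the scatter. An aminophenyl or carboxyphenyl group, or a longer alkyl chain in place of the aromatic ring, would test this, and the direction of any such shift cannot be told from these compounds.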